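The compounds below may be only part of what the source reports. "The series", "measured", "known", "first", "only" and "open" are said of these compounds alone.

The measured compounds, each with its result in a functional assay on HL-60 cells (Homo sapiens) for cytotoxicity, read by WST assay, with a stated time of 48 h; on this read-out lower numbers stand for an effect already at smaller amounts and higher numbers for an effect only at larger amounts of compound:

Compound 1 `COc1ccccc1C[C@H]1COC[C@@H]1Cc1ccc(Cl)c(Cl)c1` gives 55000 nM.
Compound 2 `Cc1ccccc1C[C@H]1COC[C@@H]1Cc1ccc(Cl)c(Cl)c1` gives 21000 nM.
Compound 3 `COc1cccc(C[C@H]2COC[C@@H]2Cc2ccc(Cl)c(Cl)c2)c1` gives 73000 nM.

Compounds 1 and 2 share one core. The change between them is methyl in place of methoxy on an aromatic carbon, and it brought a 2.6-fold lower number from compound 1 to compound 2 (0.42 log units; beyond the scatter). Compound 3 has the same atoms as compound 1 joined differently; how the two cores differ is not broken down here. Compound 3 and compound 1 lie within the scatter of each other, while compound 2 sits clearly apart from compound 3.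

Compound 4 `Cc1cccc(C[C@H]2COC[C@@H]2Cc2ccc(Cl)c(Cl)c2)c1` has not yet been measured. It arises from compound 3 by methyl in place of methoxy on an aromatic carbon. Among the compounds with values here, this is the same kind of change as the one from compound 1 to compound 2, not the same change: there the methyl stood ortho to a large group, here it stands meta to a large group. Within the data shown here, with only one earlier example of this change, the expectation rests on that single step, because a 2.6-fold lower number from compound 1 to compound 2 (0.42 log units; beyond the scatter) is the only guide to its size. The step from compound 3 to compound 4 in this assay is expected to be a 2.2-fold lower number from compound 3 to compound 4 (0.34 log units; beyond the scatter), of about the same size as the earlier one. Compound 4 is therefore estimated at 33000 nM, with a likely range from 15000 nM to 75000 nM.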

Compound 4, half-maximal effective concentration: 28000 nM
Beside the measured number, compound 4's estimate is 1.2-fold (0.07 log units) above it, within the range that was stated.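

In this assay, methyl in place of methoxy gave a 2.6-fold lower number from compound 3 to compound 4 (0.42 log units; beyond the scatter), and this step matches the earlier one on the other core: the same change on two cores in this assay, a 2.6-fold lower number (0.42 log units; beyond the scatter) from compound 1 to compound 2 and a 2.6-fold lower number (0.42 log units; beyond the scatter) from compound 3 to compound 4, 1.0-fold (0.00 log units) apart, within the scatter of two such steps. Putting 3-methylphenyl in place of 2-methylphenyl gives a 1.3-fold higher number from compound 2 to compound 4 (0.12 log units; within the scatter), so the two methyl compounds cannot be told apart in this test. The change therefore carried over unchanged in size between these two cores, but two examples do not make a rule for the whole series, and the numbers do not show why the step has this size or whether it would hold on a third core.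

The compounds shown carry only methoxy or methyl on this ring, so it remains open how a chlorine, a hydroxyl group, an amine or a carboxylic acid would read in the same place. As far as these compounds go, it also remains open whether a longer chain, such as ethyl or propyl, would continue the step seen with methyl, and whether the same step would appear in cells other than the ones used here.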